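This account rests on a few compounds, and the source may have more. Where it says the series, first, only, none or still open, it means among the compounds named here.

Of the compounds shown here, two built on a shared core have been measured so far: compound 1, `Cc1[nH]n(-c2ccc(I)cc2)c(=O)c1/N=N/c1c(O)cc(S(=O)(=O)O)c2ccccc12`, and compound 2, `Cc1[nH]n(-c2ccc(C(C)(C)C)cc2)c(=O)c1/N=N/c1c(O)cc(S(=O)(=O)O)c2ccccc12`. In an assay on BaF3 cells with thrombopoietin receptor (Homo sapiens) as the target, read by a luciferase reporter (on this read-out lower numbers stand for smaller maximal responses and higher numbers for larger maximal responses), compound 1 gives 81%, and in this assay compound 2 gives 86%. Within the data shown here, the one step that links them, a number 5 percentage points higher from compound 1 to compound 2 (within the scatter), exchanges iodo for tert-butyl on an aromatic carbon. Compound 2 thus holds the higher of the two numbers, yet the gap to compound 1 lies within the scatter, so the two compounds cannot be set in order.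

Compound 3, `Cc1[nH]n(-c2ccc(O)cc2)c(=O)c1/N=N/c1c(O)cc(S(=O)(=O)O)c2ccccc12`, remains to be measured in this assay. It differs from compound 2 in one place: hydroxy in place of tert-butyl on an aromatic carbon. Among the measured compounds shown here, no measured step involves a hydroxy group, and the only step available, a number 5 percentage points higher from compound 1 to compound 2 (within the scatter), stayed within the scatter. Nothing in the data therefore points to a move beyond the scatter in either direction. Compound 3 is expected to show a number 6 percentage points lower from compound 2 to compound 3 (within the scatter) in this assay. The value of compound 3 in this assay is estimated at 80%, with a range from 62% to 96%.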

Compound 3, largest response reached (reported as efficacy), in percent of the reference or control that the assay uses: < 5%
Compound 3 ended at the assay's limit; the forecaster's own chance of this, stated with the estimate: 0%; middle value at least 75 percentage points from the limit.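

For compound 3, < 5% in this assay is a limit of the assay and not a number: the limit of < 5% in this assay, at which 1 of the 3 values shown sits.

Hydroxy in place of tert-butyl gives a number at least 81 percentage points lower from compound 2 to compound 3 (beyond the scatter), and hydroxy in place of iodo gives a number at least 76 percentage points lower from compound 1 to compound 3 (beyond the scatter), whereas the exchange of iodo for tert-butyl had stayed within the scatter. The aromatic carbon para to a large group is therefore not a place where any group will do, which the pair of compounds 1 and 2 alone could not reveal: of the three groups shown there, iodo and tert-butyl keep a high maximal response and hydroxy does not.

Three groups at one place cannot tell which feature of hydroxy goes with the loss of response, and the data offer no explanation of it. Going by these compounds, whether a methoxy group, an amine or a carboxylic acid at the same place would keep the response, as iodo and tert-butyl do, or lose it, as hydroxy does, stays open.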